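A few compounds are considered here, and "the series" means these few. Any claim that something is new, unique, unknown or untested is made for them only; others in the source may bear on it.

Measured in an assay on Sf9 cells for inhibition of Amine oxidase [flavin-containing] B (Homo sapiens), with stated times of 15 min and 60 min; on this read-out lower numbers stand for stronger inhibition and higher numbers for weaker inhibition:
compound 1, `CC1(C)C[C@@H](C(N)=O)N(Cc2ccc(OCc3cccc(F)c3)cc2F)C1`: 6350 nM
compound 2, `C#CCN(Cc1ccc(OCc2cccc(F)c2)cc1)[C@@H](C)C(N)=O`: 530 nM
compound 3, `Cc1cc(OCc2cccc(F)c2)ccc1CN[C@@H](C)C(N)=O`: 69 nM

Compound 1 gives the highest of the three numbers: compound 2 stands at a clearly lower number and compound 3 at a far lower one, both gaps beyond the scatter. Compounds 2 and 3 differ from compound 1 in several places at once, so no single step can be read off from them. Compound 4, `CC1(C)C[C@@H](C(N)=O)N(Cc2ccc(OCc3cccc(F)c3)cc2)C1`, remains to be measured in this assay. It differs from compound 1 by hydrogen in place of fluoro on an aromatic carbon. With no measured step of this kind in the series, the expectation is a modest move towards a lower number, of a size that may not exceed the scatter, as given by a 1.8-fold lower number from compound 1 to compound 4 (0.26 log units; within the scatter). Compound 4 is accordingly estimated at 3500 nM, within 900 nM to 14000 nM.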

Compound 4, half-maximal inhibitory concentration: 1420 nM
Compound 4: the middle estimate sits 2.5-fold (0.39 log units) above what was measured; the measured number falls inside the stated range.
By their numbers in this assay, from the lowest: compound 3; then compound 2; then compound 4; then compound 1.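

In this assay, hydrogen in place of fluoro on this aromatic carbon, ortho to a large group, gives a 4.5-fold lower number from compound 1 to compound 4 (0.65 log units; beyond the scatter) and is the only single-place step shown in the series. On the core of compound 1, fluoro at this carbon therefore goes with the higher number, though this rests on one pair alone. Nothing measured here accounts for the step.

As far as these compounds go, whether a chloro or methoxy group at this carbon would fall nearer fluoro or hydrogen remains open. So does whether the same change carries the same size on the open-chain amides, compound 2 and compound 3.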